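A few compounds are considered here, and "the series" means these few. Any claim that something is new, unique, unknown or untested is made for them only; others in the source may bear on it.

Within the data shown here, in a functional assay on OVCAR-3 cells (Homo sapiens) for inhibition, read by MTT assay, with a stated time of 24 h (a lower number here means a stronger inhibitor, a higher number a weaker inhibitor), two compounds have numbers so far. Compound 1 (`CC1(C)[C@H]2CC[C@]1(C)N(Cc1cn(-c3cccc(C#N)c3)nn1)C(=O)C2`) gives 230 nM, and compound 2 (`Cc1ccccc1-n1cc(CN2C(=O)C[C@@H]3CC[C@@]2(C)C3(C)C)nn1`) gives 150 nM. These values lie within the scatter of each other, so compound 2 stands level with compound 1, and neither can be called the better inhibitor.

Compound 3 (`CC1(C)[C@H]2CC[C@]1(C)N(Cc1cn(-c3cccc(Br)c3)nn1)C(=O)C2`) keeps the shared core and differs from compound 2 only in the group on the triazole-like ring's aromatic nitrogen: 3-bromophenyl in place of 2-methylphenyl on an aromatic nitrogen. In plain terms, 3-bromophenyl comes in place of 2-methylphenyl on an aromatic nitrogen.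

Among the measured compounds shown here, only one measured step bears on this change: a 1.5-fold lower number from compound 1 to compound 2 (0.19 log units; within the scatter). It exchanged groups at that same place and stayed within the scatter. For the measured compounds named here, the 3-bromophenyl of compound 3 resembles the 3-cyanophenyl of compound 1 in its name, but no measured compound carries bromine, so the evidence is thin. With so little to go on, no real shift is expected. In this assay the estimated step is a 1.2-fold higher number from compound 2 to compound 3 (0.08 log units; within the scatter), which would lie within the scatter. For compound 3 the estimated value is 180 nM, with an expected range of 70 nM to 450 nM.


Correction to the second paragraph: for "the triazole-like ring's aromatic nitrogen" read "an aromatic nitrogen of a five-membered aromatic ring with 3 nitrogen".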

Compound 3, half-maximal inhibitory concentration: 30 nM
Compound 3: middle estimate off by 6.0-fold (0.78 log units), on the high side; the measured number lies below the stated range.
By their numbers in this assay, from the lowest: compound 3; then compounds 2 and 1 (each within the scatter of the next).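

In this assay, the group on the aromatic nitrogen of the five-membered aromatic ring with 3 nitrogen can move the number beyond the scatter, as 3-bromophenyl in place of 2-methylphenyl gives a 5.0-fold lower number from compound 2 to compound 3 (0.70 log units; beyond the scatter), although the two groups have the same count of heavy atoms and neither has a hydrogen-bond donor or acceptor. The tightest comparison is bromo in place of cyano on an aromatic carbon, with everything else in the molecule unchanged, and it gives a 7.7-fold lower number from compound 1 to compound 3 (0.88 log units; beyond the scatter), so the identity of this one group on the phenyl ring matters in this series. No measurement available here explains why bromo goes with the lower number.

On these data alone, whether this gain belongs to bromine in particular stays open, and a chloro, iodo or methoxy group on that same aromatic carbon would help to settle it. The step between compound 2 and compound 3 also changes both the kind of group and its place on the phenyl ring, and the compounds shown do not separate those two changes.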